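The compounds below may be only part of what the source reports. "The series", "measured", "known", "first", "only" and "open" are said of these compounds alone.

Compounds measured so far:

Compound 1, `CC(C)C(C(=O)Nc1ncccn1)c1ccc(Cl)cc1`: 53000 nM
Compound 2, `CC(C)[C@H](C(=O)Nc1cccnn1)c1ccc(Cl)cc1`: 2300 nM

Both compounds share a core in which an amide links a branched acid bearing a chlorophenyl group to a small aromatic ring on the amide nitrogen. In a functional assay on CHO cells for agonist activity at Free fatty acid receptor 2 (Homo sapiens), read by cAMP accumulation (a lower number here means a stronger inhibitor, a higher number a weaker inhibitor), compound 1 gives 53000 nM, while compound 2 gives 2300 nM. Of these two numbers, compound 2 holds the lower one; the gap to compound 1, its nearest neighbour, lies beyond the scatter of repeated measurements, so compound 2 is the stronger of the two on what has been measured.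

Compound 3, `Cc1csc(NC(=O)[C@H](c2ccc(Cl)cc2)C(C)C)n1`, is the next compound to be tested in this assay. It differs from compound 2 in one place: 4-methyl-1,3-thiazol-2-yl in place of pyridazin-3-yl on an amide-type nitrogen. Among the measured compounds shown here, no directly comparable step between measured compounds exists for this kind of exchange, so the size of the effect is uncertain. The expectation is that compound 3 will give a somewhat lower number than compound 2, a step of a 3.8-fold lower number from compound 2 to compound 3 (0.58 log units; beyond the scatter), though a result within the scatter of compound 2 would not be surprising. For compound 3 the estimated value is 600 nM, with a range from 120 nM to 3000 nM.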

Compound 3, half-maximal inhibitory concentration: 1400 nM
Compound 3: the middle estimate sits 2.3-fold (0.37 log units) below what was measured, and the stated range covers the measured number.
By their numbers in this assay, from the lowest: compounds 3 and 2 (each within the scatter of the next); then compound 1.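

In this assay, putting 4-methyl-1,3-thiazol-2-yl in place of pyridazin-3-yl on the amide-type nitrogen gives a 1.6-fold lower number from compound 2 to compound 3 (0.22 log units; within the scatter), so the two compounds cannot be told apart in this read-out. Among the compounds shown here, this is the first step measured at this position, and it shows that a six-membered aromatic ring can be exchanged for a five-membered one that contains sulfur and carries a methyl group, with the same count of heavy atoms, without the number leaving the scatter. No measurement shown here explains why the number holds through this exchange, or what either ring contributes.

Because the entering group differs from the leaving one in ring size, ring atoms and the methyl group all at once, this single step cannot separate those changes, and the plain 1,3-thiazol-2-yl group would be needed to isolate the methyl. On these data alone, how far this position tolerates other groups also stays open, for example a phenyl ring, a ring bearing an amine or a carboxylic acid, or a longer chain in place of the methyl.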